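Swapping dimethylamino for methyl on a bis-benzylidene cyclohexanone

A few compounds are considered here, and "the series" means these few. Any claim that something is new, unique, unknown or untested is made for them only; others in the source may bear on it.

Measured so far:
Compound 1, `COc1cc(/C=C2\CCC/C(=C\c3ccccc3[N+](=O)[O-])C2=O)cc(OC)c1OC`, gives 1520 nM.
Compound 2, `CN(C)c1ccc(/C=C2\CCC/C(=C\c3ccccc3[N+](=O)[O-])C2=O)cc1`, gives 164000 nM.

Both compounds were tested in a functional assay on L1210 cells (Mus musculus) for cytotoxicity, with a stated time of 48 h; on this read-out higher numbers stand for weaker inhibition and lower numbers for stronger inhibition. Compound 2 holds the highest number of the two, and its gap to compound 1 is beyond the usual scatter, so compound 2 is the weaker of the pair on this read-out.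

Compound 3, `Cc1ccc(/C=C2\CCC/C(=C\c3ccccc3[N+](=O)[O-])C2=O)cc1`, has not yet been measured. It differs from compound 2 in one place: methyl in place of dimethylamino on an aromatic carbon. Among the compounds with values here, since no pair of measured compounds shows this same change, the size of the step cannot be read from the data. Within the data shown here, the only guide is that compound 2 sits far above compound 1, which leaves ample room for the number to come down. The expectation for the step from compound 2 to compound 3 is therefore a drop beyond the scatter, an 8.2-fold lower number from compound 2 to compound 3 (0.91 log units; beyond the scatter), with wide uncertainty. Compound 3 is estimated at 20000 nM, in a range from 3000 nM to 120000 nM.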

Compound 3, half-maximal inhibitory concentration: 7770 nM
The estimate for compound 3 lay 2.6-fold (0.41 log units) above the measured number, and the stated range covers the measured number.
By their numbers in this assay, from the lowest: compound 1; then compound 3; then compound 2.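

In this assay, the group on this aromatic carbon has a large influence on the number: putting methyl in place of dimethylamino gives a 21-fold lower number from compound 2 to compound 3 (1.32 log units; beyond the scatter). Within the data shown here, this is the first step where only one place changes, so the whole gap between these two compounds belongs to this swap, with the rest of the structure held the same. The swap takes away a nitrogen, two carbons and a hydrogen-bond acceptor all at once, and no measurement here bears on why the number moves.

A single pair cannot show whether the gain comes from losing dimethylamino or from having methyl on this carbon in particular. A plain hydrogen, a chlorine atom or a longer chain such as ethyl at the same place would help separate those two readings, and an unsubstituted amine would show whether the nitrogen itself goes with the weak number or only the two carbons attached to it.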